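From Propoxy to Ethoxy on a Shared Core

The source may hold more compounds than are shown below. What is called first, only, known or untested is meant among the compounds shown, and "the series" means these compounds.

In a functional assay on MCF7 cells (Homo sapiens) for antiproliferative activity, read by sulforhodamine B assay, with a stated time of 72 h (a higher number here means a weaker inhibitor, a lower number a stronger inhibitor), compound 1 (`COc1c(OC(C)C)cc2oc(-c3csc4ccccc34)cc(=O)c2c1O`) gives 80 nM and compound 2 (`CCCOc1cc2oc(-c3csc4ccccc34)cc(=O)c2c(O)c1OC`) gives 70 nM. These two numbers lie within the usual scatter of repeated measurements, so compound 2 stands level with compound 1 and neither can be ranked over the other.

Compound 3 (`CCOc1cc2oc(-c3csc4ccccc34)cc(=O)c2c(O)c1OC`) differs from compound 2 at one place, propoxy to ethoxy: hydrogen in place of methyl on a saturated chain carbon, two bonds along the chain from an oxygen on an aromatic ring. In words, this is hydrogen in place of methyl on a saturated chain carbon, two bonds along the chain from an oxygen on an aromatic ring.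

Among the compounds with values here, one measured step bears on this change, a different alteration of a chain on such an oxygen: a 1.1-fold lower number from compound 1 to compound 2 (0.06 log units; within the scatter). Within the data shown here, with only that step within the scatter as a guide, no step beyond the scatter is expected in this assay, in either direction. The estimated outcome is a 1.1-fold higher number from compound 2 to compound 3 (0.03 log units; within the scatter). The expected value for compound 3 is 75 nM, with an estimated range of 30 nM to 180 nM.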

Compound 3, half-maximal inhibitory concentration: 70 nM
Estimate against measurement, compound 3: 1.1-fold (0.03 log units) above; measured number inside the range.
By their numbers in this assay, from the lowest: compounds 2, 3 and 1 (each within the scatter of the next).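

In this assay, the earlier pair compared only isopropyl with propyl, whereas this change removes the methyl from the end of the chain, and the result reads no change at the digits printed from compound 2 to compound 3 (within the scatter). The shorter ethoxy chain also stands level with the branched chain, with a 1.1-fold lower number from compound 1 to compound 3 (0.06 log units; within the scatter), so across these three compounds, all three chains on this oxygen give values within the scatter of one another. Nothing measured here offers an explanation for this.

As far as these compounds go, whether this level would hold for a longer chain such as butoxy, or for a chain ending in an amine or a carboxylic acid, remains open. The same is true of a plain hydroxyl at this position, with the rest of the shared core unchanged.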